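This account rests on a few compounds, and the source may have more. Where it says the series, first, only, none or still open, it means among the compounds named here.

Measured compounds and their values:

- compound 3, `Nc1nc2c(Cl)c(Cl)ccc2n1COCCO`: > 100000 nM
- compound 1, `CNc1nc2cc(Cl)c(Cl)cc2n1COCCO`: > 100000 nM
- compound 2, `OCCOCn1c(SCc2ccccc2)nc2c(Cl)cc(Cl)cc21`: > 100000 nM

Compound 3 gives no number in a functional assay on KB cells (Homo sapiens) for inhibition (on this read-out higher numbers stand for weaker inhibition and lower numbers for stronger inhibition), only a limit of the assay. The same holds for compound 1 and compound 2, and so every value shown is a limit, as stated by the limit of > 100000 nM in this assay, at which 3 of the 3 values shown sit. Going by the values given here, nothing here places compound 3 higher or lower than its companions, and no step between two measured compounds that differ in one place has been measured, so no size of change can be read from the data.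

Compound 4, `OCCOCn1c(S)nc2c(Cl)c(Cl)ccc21`, differs from compound 3 by sulfanyl in place of amino on an aromatic carbon. With all three measured values sitting at the limit, the expectation for this change in this assay is a step of no size beyond the scatter, in no particular direction: compound 4 is expected to remain at the limit as well. Compound 4 is therefore estimated at 100000 nM, with a range from 30000 nM to 300000 nM. The expected step is a number no higher from compound 3 to compound 4 (the limit leaves the size open).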

Compound 4, half-maximal inhibitory concentration: > 100000 nM
Compound 4 ended at the assay's limit (the forecaster's own chance of this, stated with the estimate: 80%); the middle value sits exactly at the limit.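

No step can be read from compound 3 to compound 4, because both stand at a limit rather than at a number: the limit of > 100000 nM in this assay, at which 4 of the 4 values shown sit.

The compounds shown leave open which change to the shared core, if any, would give a measurable value in this assay.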